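Swapping an amino for chloro on a purine-like core

A few compounds are considered here, and "the series" means these few. Any claim that something is new, unique, unknown or untested is made for them only; others in the source may bear on it.

Measured compounds:
- compound 1 `ClCc1ccc(Cn2cnc3c(Cl)ncnc32)cc1`: 13800 nM
- compound 2 `Nc1nc(Cl)c2ncn(Cc3ccccc3CCl)c2n1`: 52500 nM
- compound 3 `ClCc1ccccc1Cn1cnc2nc(Cl)nc(Cl)c21`: 20900 nM

Of the compounds shown here, three have been tested in a functional assay on SK-OV-3 cells (Homo sapiens) for cytotoxicity, read by sulforhodamine B assay, with a stated time of 48 h; on this read-out higher numbers stand for weaker inhibition of growth and lower numbers for stronger inhibition of growth. In this assay compound 1 gives 13800 nM and compound 3 gives 20900 nM. Compound 2 stands highest of the three, so it inhibits growth least; its number lies beyond the usual scatter above both compound 3 and compound 1, so the ordering is real rather than noise.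

The next compound, compound 4 `ClCc1ccccc1Cn1cnc2c(Cl)nc(Cl)nc21`, has not yet been measured. It differs from compound 2 in a single place: chloro in place of amino on an aromatic carbon. Compound 4 thus carries two chloro groups on its core, as compound 3 does, and a chloromethyl on the same part of the benzyl arm as compound 3.

Going by the values given here, no step between two measured compounds that differ in one place is available to calibrate this change. The expectation for compound 4 rests on compound 3, whose value 20900 nM suggests that a core with two chloro groups gives a lower number than compound 2. A modest step towards stronger growth inhibition, a 2.6-fold lower number from compound 2 to compound 4 (0.42 log units; beyond the scatter), is therefore expected in this assay, though it could fall within the scatter. Compound 4 is estimated at 20000 nM, with a range from 8000 nM to 50000 nM.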

Compound 4, concentration for total growth inhibition: 3540 nM
For compound 4 the middle estimate is 5.6-fold (0.75 log units) above the measured one; the measured number lies below the stated range.
By their numbers in this assay, from the lowest: compound 4; then compounds 1 and 3 (each within the scatter of the next); then compound 2.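

In this assay, putting chloro in place of amino on the aromatic carbon between two ring nitrogen atoms gives a 15-fold lower number from compound 2 to compound 4 (1.17 log units; beyond the scatter), a large step well beyond the usual scatter. Going by these compounds alone, this is the only comparison so far of two compounds that differ in one place, so it is the first direct reading of what a single change does on this core. It shows that this carbon is far from a silent spot, since the choice between amino and chloro there strongly shifts the concentration needed for total growth inhibition. Nothing shown here explains why the swap has so large an effect.

From the compounds shown here alone, because this is a single pair, it remains open where other groups at this carbon, such as methoxy or methylamino, would fall relative to amino and chloro. Going by these compounds, it also remains open whether the same swap would give a step of similar size with the chloromethyl placed on the benzyl arm as it is in compound 1.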